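From carboxy to chloro in a cytotoxicity read-out

The compounds below may be only part of what the source reports. "The series", "measured", "known", "first", "only" and "open" are said of these compounds alone.

Compound 1 (`O=C1Nc2ccc(S(=O)(=O)N3CCOCC3)cc2/C1=N/c1cccc(C(F)(F)F)c1`): 15900 nM
Compound 2 (`O=C1Nc2ccc(S(=O)(=O)N3CCOCC3)cc2/C1=N/c1ccc(C(=O)O)cc1`): 23600 nM

In a functional assay on HCT-116 cells (Homo sapiens) for cytotoxicity, read by sulforhodamine B assay, with a stated time of 24 h (on this read-out higher numbers stand for weaker inhibition and lower numbers for stronger inhibition), compound 2 stands at 23600 nM and lies within the scatter of compound 1, so these two numbers do not separate the compounds. Compound 3 (`O=C1Nc2ccc(S(=O)(=O)N3CCOCC3)cc2/C1=N/c1ccc(Cl)cc1`) has yet to be measured. It carries chloro in place of carboxy on an aromatic carbon, para to a large group, which turns 4-carboxyphenyl into 4-chlorophenyl (chloro in place of carboxy on an aromatic carbon).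

Within the data shown here, only one measured step bears on this change: a 1.5-fold higher number from compound 1 to compound 2 (0.17 log units; within the scatter). That step also exchanged the group on the double-bonded nitrogen, putting 4-carboxyphenyl in place of 3-(trifluoromethyl)phenyl. Among the measured compounds shown here, no measured compound carries chloro, so the evidence is indirect and thin. With that single step inside the scatter, no step beyond the scatter is expected in this assay here. The estimated change is a 1.4-fold lower number from compound 2 to compound 3 (0.14 log units; within the scatter). Compound 3 is expected at about 17000 nM, with an estimated range from 8000 nM to 35000 nM.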

Compound 3, half-maximal inhibitory concentration: 24300 nM
Compound 3: the middle estimate sits 1.4-fold (0.16 log units) below what was measured, and the stated range covers the measured number.
By their numbers in this assay, from the lowest: compounds 1, 2 and 3 (each within the scatter of the next).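

In this assay, the direct exchange of carboxy for chloro on an aromatic carbon, para to a large group, gives a 1.0-fold higher number from compound 2 to compound 3 (0.01 log units; within the scatter), so compound 2 and compound 3 are not separated by this read-out. Among these compounds, this is the first reading of that exchange alone, since the earlier step also moved from 3-(trifluoromethyl)phenyl to a group with a different substituent at a different place on the ring. The new comparison of that kind, a 1.5-fold higher number from compound 1 to compound 3 (0.18 log units; within the scatter), with 4-chlorophenyl in place of 3-(trifluoromethyl)phenyl on the double-bonded nitrogen, shows that none of the three substituted phenyl groups shown stands apart here, and nothing available offers an explanation for this lack of separation.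

On these data alone, whether an amine, a methoxy group or a longer chain on the same aromatic carbon would move the number beyond the scatter remains open. As far as these compounds go, it is also open whether a change elsewhere on the shared core, rather than on this phenyl group, would separate compounds in this assay.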